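Fluorine on Two Cores and Microsomal Clearance

The compounds below may be only part of what the source reports. "The series", "measured", "known", "first", "only" and "open" are said of these compounds alone.

Compound 1 `c1ccc(CNc2nnc(-c3ccc4cnccc4c3)o2)cc1` gives 120 mL.min-1.g-1 in an ADME assay (liver) for metabolic stability, with Liver microsome (Homo sapiens) as the target, using microsomes; on this read-out lower numbers stand for slow clearance and higher numbers for fast clearance. Compound 2 `Fc1cc2cc(-c3nnc(NCc4ccccc4)o3)ccc2cn1` carries fluoro in place of hydrogen on an aromatic carbon and reaches 49 mL.min-1.g-1; this change gave a 2.4-fold lower number from compound 1 to compound 2 (0.39 log units; beyond the scatter). Compound 3 `c1ccc([C@H](Nc2nnc(-c3c[nH]c4ncccc34)o2)C2CC2)cc1` sits on a different core, and the difference between the two cores is not broken down here; in this assay compound 3 gives 56 mL.min-1.g-1, within the scatter of compound 2 and beyond it relative to compound 1. Compound 4 `Fc1ccccc1[C@H](Nc1nnc(-c2c[nH]c3ncccc23)o1)C1CC1` is not yet measured and differs from compound 3 by fluoro in place of hydrogen on an aromatic carbon, the same kind of change as that from compound 1 to compound 2, though the place differs: there the fluoro enters a six-membered aromatic ring with one nitrogen, next to the ring nitrogen, whereas here it enters a ring of carbon only, ortho to a large group. For the measured compounds named here, because the single measured step of a 2.4-fold lower number from compound 1 to compound 2 (0.39 log units; beyond the scatter) was modest and sat on another ring, a smaller step, a 1.3-fold lower number from compound 3 to compound 4 (0.12 log units; within the scatter), is expected. Compound 4 is therefore estimated at 42 mL.min-1.g-1, with a likely range from 22 mL.min-1.g-1 to 80 mL.min-1.g-1.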

Compound 4, intrinsic clearance in microsomes: 59 mL.min-1.g-1
Compound 4: the middle estimate sits 1.4-fold (0.15 log units) below what was measured; the measured number falls inside the stated range.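

In this assay the exchange of phenyl for 2-fluorophenyl gave a 1.1-fold higher number from compound 3 to compound 4 (0.02 log units; within the scatter), so on the core of compound 3 the change leaves no readable mark on clearance. Set beside the earlier step, the two results cannot be told apart: the same change on two cores in this assay, a 2.4-fold lower number (0.39 log units; beyond the scatter) from compound 1 to compound 2 and a 1.1-fold higher number (0.02 log units; within the scatter) from compound 3 to compound 4, 2.6-fold (0.41 log units) apart, within the scatter of two such steps. For the compounds shown here, this does not show that the change carries over from one core to the other with a constant size, since only two steps are at hand, they differ in the ring that takes the fluoro as well as in the core, and one lies beyond the scatter while the other lies within it.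

The compounds shown leave open whether fluoro on the ring of carbon only would give a different step on the core of compound 1, and whether the step seen from compound 1 to compound 2 has a counterpart on the core of compound 3. They also leave open how chloro, methoxy or a nitrile in place of that same hydrogen would read.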